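Replacing the anilino of a urea by a vinyl group

A few compounds are considered here, and "the series" means these few. Any claim that something is new, unique, unknown or untested is made for them only; others in the source may bear on it.

Compound 1 `CCOC(=O)c1csc2nc(-c3ccc(NC(=O)CC)cc3)cn12` carries a propanoyl amide on its aromatic ring. In a functional assay on MV4-11 cells (Homo sapiens) for cytotoxicity, read by MTT assay, with a stated time of 72 h (on this read-out lower numbers stand for stronger inhibition and higher numbers for weaker inhibition), compound 1 gives 9520 nM. Compound 2 `CCOC(=O)c1csc2nc(-c3ccc(NC(=O)Nc4ccccc4)cc3)cn12` carries a urea instead. In this assay compound 2 gives only a limit, > 20000 nM, so compound 2 stands at the weak end of the two values shown. Within the data shown here, the one measured step, an at least 2.1-fold higher number from compound 1 to compound 2 (0.32 log units; beyond the scatter), is the replacement of ethyl by anilino, and the limit of > 20000 nM in this assay, at which 1 of the 2 values shown sits, marks where that step ends.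

Compound 3 `C=CC(=O)Nc1ccc(-c2cn3c(C(=O)OCC)csc3n2)cc1` differs from compound 2 by vinyl in place of anilino on a carbonyl carbon. This removes the very group whose arrival weakened compound 1 and puts a small two-carbon group in its place, so the expected direction is toward stronger inhibition, with compound 1 as the nearest guide. For compound 3 the expected step is an at least 2.8-fold lower number from compound 2 to compound 3 (0.45 log units; beyond the scatter), and the estimate is 7000 nM, within a range from 1200 nM to 25000 nM.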

Compound 3, half-maximal inhibitory concentration: 2930 nM
Beside the measured number, compound 3's estimate is 2.4-fold (0.38 log units) above it; low and high end bracket the measured number.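

Within this assay, vinyl in place of anilino gives an at least 6.8-fold lower number from compound 2 to compound 3 (0.83 log units; beyond the scatter) on the same carbonyl carbon, so this position can move toward stronger inhibition as well as weaker. Vinyl in place of ethyl gives a 3.2-fold lower number from compound 1 to compound 3 (0.51 log units; beyond the scatter) and shows that even two small groups at this place can be told apart, beyond the usual scatter. The first of these steps has only a minimum size because compound 2 carries a limit rather than a number: the limit of > 20000 nM in this assay, at which 1 of the 3 values shown sits.

Why vinyl gives a lower number than ethyl remains open, since these values cannot separate the double bond from any other explanation. Going by these compounds, it is also open whether a longer chain such as butyl, or a vinyl group bearing an amine, would extend or reverse the trend at this carbonyl carbon.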